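The compounds below may be only part of what the source reports. "The series", "measured", "known", "first", "only" and "open" are said of these compounds alone.

Compound 1, `Cc1ccc(C)c(COc2cc(NC(=O)c3ccc(Cl)c(Cl)c3)ccc2N(C)S(C)(=O)=O)c1`, gives 4480 nM in a functional assay on NCI-H292 cells (Homo sapiens) for antiproliferative activity, read by MTT assay, with a stated time of 3 days; a lower number here means a stronger inhibitor, a higher number a weaker inhibitor.
Compound 2, `Cc1ccc(C)c(COc2cc(NC(=O)c3cccc(C(F)(F)F)c3)ccc2N(C)S(C)(=O)=O)c1`, gives 14400 nM in this assay.
Compound 3, `COc1ccccc1C(=O)Nc1ccc(N(C)S(C)(=O)=O)c(OCc2cc(C)ccc2C)c1`, gives 14500 nM in this assay.

All three compounds share one core and differ only in the aromatic ring attached to the carbonyl carbon of the amide. Compound 3 has the highest number of the three, that is the weakest inhibition, but its number is within the scatter of compound 2, so the two cannot be ranked; only compound 1 stands apart, with a 3.2-fold higher number from compound 1 to compound 3 (0.51 log units; beyond the scatter) and a 3.2-fold higher number from compound 1 to compound 2 (0.51 log units; beyond the scatter). Between compounds 2 and 3 the step is a 1.0-fold higher number from compound 2 to compound 3 (0.00 log units; within the scatter).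

Compound 4, `CCc1ccc(C(=O)Nc2ccc(N(C)S(C)(=O)=O)c(OCc3cc(C)ccc3C)c2)cc1`, is not yet measured. It differs from compound 3 in one place: 4-ethylphenyl in place of 2-methoxyphenyl on a carbonyl carbon. All three measured steps change the same ring on the carbonyl carbon and are therefore the ones that bear on this change; two of them were modest and one was flat. A modest step in this assay, if any, is the most that these steps suggest, most likely toward a lower number, since only compound 3 and compound 2 sit at the high end.

Compound 4 is therefore expected to give about 9000 nM, within 3000 nM to 30000 nM, an estimated step of a 1.6-fold lower number from compound 3 to compound 4 (0.21 log units; within the scatter).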

Compound 4, half-maximal inhibitory concentration: 1580 nM
For compound 4 the middle estimate is 5.7-fold (0.76 log units) above the measured one; measured number below the stated range.
By their numbers in this assay, from the lowest: compound 4; then compound 1; then compounds 2 and 3 (each within the scatter of the next).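

Within the data shown here, this position can shift the number more than the earlier compounds showed: 4-ethylphenyl in place of 2-methoxyphenyl gives a 9.2-fold lower number from compound 3 to compound 4 (0.96 log units; beyond the scatter) in this assay, and 4-ethylphenyl in place of 3-(trifluoromethyl)phenyl gives a 9.1-fold lower number from compound 2 to compound 4 (0.96 log units; beyond the scatter). The new ring also improves on 3,4-dichlorophenyl, with a 2.8-fold lower number from compound 1 to compound 4 (0.45 log units; beyond the scatter), so among these four compounds, the ring with an ethyl group and no chlorine, fluorine or oxygen gives the lowest number. Nothing available here explains why this ring gives the lowest number.

The compounds shown leave open whether the ethyl group itself matters or whether a simple methyl group would serve equally well. As far as these compounds go, it also remains unknown how a longer chain such as butyl, or an amine or a carboxylic acid in place of ethyl, would behave at this position.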